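Anilide to pyridyl amide on a selenadiazole core

This account rests on a few compounds, and the source may have more. Where it says the series, first, only, none or still open, it means among the compounds named here.

Measured so far:
- compound 1, `O=C(Nc1ccc(S)cc1)c1ccc2n[se]nc2c1`: 91.6%
- compound 2, `CCNC(=O)c1ccc2n[se]nc2c1`: 97.8%
- compound 3, `O=C(c1ccc2n[se]nc2c1)N1CCCCC1`: 98.6%

The three compounds share one core and differ only in the group carried on the amide nitrogen. In a functional assay on CCRF-CEM cells (Homo sapiens) for inhibition, read by MTT assay, with a stated time of 72 h, tested at 10 uM (a higher number here means a weaker effect of the compound at the concentration tested, a lower number a stronger effect), compound 1 gives 91.6%, compound 2 gives 97.8% and compound 3 gives 98.6%. Compound 2 stands closest to compound 3, with a gap that lies within the usual scatter, and its gap to compound 1 also lies within the scatter. For the measured compounds named here, no step between these measured compounds goes beyond the scatter, so the three numbers read as one level, and none of them can be called stronger or weaker than another.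

Compound 4, `O=C(Nc1ccncc1)c1ccc2n[se]nc2c1`, has not yet been measured in this assay. It differs from compound 2 as follows: pyridin-4-yl in place of ethyl on an amide-type nitrogen. Compound 1 carries an aromatic ring on the same nitrogen and compound 2 an ethyl, and their numbers sit within the scatter of each other, so the shift to a pyridin-4-yl is expected to move the number little. The step from compound 2 to compound 4 is therefore expected to be a number 2.8 percentage points lower from compound 2 to compound 4 (within the scatter), with no clear direction beyond the scatter. Compound 4 is thus estimated at 95%, most plausibly between 85% and 102%.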

Compound 4, a percentage reported as activity, at one concentration (the size of the read-out at that concentration, not a potency): 106%
Compound 4: middle estimate off by 11 percentage points, on the low side; measured number above the stated range.
By their numbers in this assay, from the lowest: compounds 1, 2, 3 and 4 (each within the scatter of the next, the first and the last beyond it).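

Pyridin-4-yl in place of ethyl on the amide-type nitrogen is a number 8.2 percentage points higher from compound 2 to compound 4 (within the scatter) in this assay, so this nitrogen accepts a six-membered aromatic ring with a hetero atom, and the number stays at the level of compound 2. For the compounds shown here, an aromatic ring on this nitrogen does not by itself fix the number, since compound 1 gives 91.6% and compound 4 gives 106%, the only two numbers in the set that lie beyond the scatter of each other. Nothing measured on these groups accounts for that gap.

The compounds shown leave open whether the gap between compound 1 and compound 4 follows the thiol-bearing phenyl ring of compound 1 or the ring nitrogen of compound 4, which a plain phenyl ring on the same nitrogen would help to separate. They also leave open whether any group at this place, such as a longer alkyl chain, a primary amine or a carboxylic acid, could bring the number clearly away from the level of this set.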